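Bromo for trifluoromethoxy at a solubility limit

The source may hold more compounds than are shown below. What is called first, only, known or untested is meant among the compounds shown, and "the series" means these compounds.

In a physicochemical assay for solubility, using the shake flask method, in simulated intestinal fluid, measured as kinetic solubility, with a stated time of 2 h, at 25 degrees C, at pH 6.5 (a lower number here means a less soluble compound, a higher number a more soluble compound), three compounds have been measured so far:
compound 1 `Cc1noc(-c2nc(C)c3c(c2N)C(=O)N(Cc2ccc(Cl)cc2)C3=O)n1` gives < 5000 nM as a limit
compound 2 `COc1ccc(CN2C(=O)c3c(C)nc(-c4nc(C)no4)c(N)c3C2=O)cc1` gives < 5000 nM as a limit
compound 3 `Cc1noc(-c2nc(C)c3c(c2N)C(=O)N(Cc2ccc(OC(F)(F)F)cc2)C3=O)n1` gives < 5000 nM as a limit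

Compound 3 stands at < 5000 nM which is a limit and not a number. The other two compounds offer no exact number to start from either, since the set shows the limit of < 5000 nM in this assay, at which 3 of the 3 values shown sit, and nothing more.

The next compound is compound 4 `Cc1noc(-c2nc(C)c3c(c2N)C(=O)N(Cc2ccc(Br)cc2)C3=O)n1` and it keeps the shared core. The change from compound 3 is bromo in place of trifluoromethoxy on an aromatic carbon and it falls on an aromatic carbon of a six-membered aromatic ring of carbon only, para to a large group.

Three measured steps swap groups at that same place. Trifluoromethoxy in place of chloro is a step that the two limits leave unreadable from compound 1 to compound 3 and methoxy in place of chloro is a step that the two limits leave unreadable from compound 1 to compound 2 while the swap between the two oxygen-linked groups is a step that the two limits leave unreadable from compound 2 to compound 3 in this assay so none of them gives a size to carry over.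

With no readable step to build on, no change beyond the usual scatter is expected, and the result may well be another limit. The expected step is a step that the limit leaves unreadable from compound 3 to compound 4 and it is estimated to stay within that scatter. Compound 4 is expected at 3000 nM with an estimated range from 1000 nM to 5000 nM in this measurement.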

Compound 4, solubility: < 5000 nM
Compound 4 was reported as a limit; the forecaster's own chance of this, stated with the estimate: 90%; the middle value does not contradict the limit.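

In this assay compound 4 gives < 5000 nM, which is a limit and not a number. Its steps from compound 1, compound 2 and compound 3 cannot be read, and the whole set sits at one value: the limit of < 5000 nM in this assay, at which 4 of the 4 values shown sit.

The compounds shown leave open whether bromo, chloro, methoxy and trifluoromethoxy differ at all in this assay.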